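A few compounds are considered here, and "the series" means these few. Any claim that something is new, unique, unknown or untested is made for them only; others in the source may bear on it.

Compound 1 `O=C(O)c1c(O)cccc1CCc1ccc2ccccc2c1`, compound 2 `O=C(O)c1c(O)cc(Cl)cc1CCc1ccc2ccccc2c1` and compound 3 `COc1cc(Cl)cc(C=Cc2ccc3ccccc3c2)c1C(=O)O` were tested in an ADME assay on HepG2 cells (Homo sapiens) for cytotoxicity, read by resazurin assay, with a stated time of 24 h; a lower number here means that less compound is tolerated, a higher number that more compound is tolerated. Compound 2 gives 35000 nM, and compound 3 gives 104000 nM. Compound 1 reaches only a limit of the assay, > 100000 nM. Compounds 2 and 1 differ in one place, (hydrogen in place of chloro on an aromatic carbon), and this change gives an at least 2.8-fold higher number from compound 2 to compound 1 (0.45 log units; beyond the scatter); the step is known only as a lower bound because compound 1 sits at the limit of > 100000 nM in this assay, at which 1 of the 3 values shown sits.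

Compound 4 `COc1cccc(C=Cc2ccc3ccccc3c2)c1C(=O)O` is not yet measured. It differs from compound 3 by the same kind of change, (hydrogen in place of chloro on an aromatic carbon); around the place, the carbon is meta to a methoxy group here, where in compound 2 it is meta to a hydroxy group. How the core of compound 3 differs from that of compound 2 is not broken down here.

In this assay compound 4 is expected to show a 1.4-fold higher number from compound 3 to compound 4 (0.16 log units; within the scatter), resting on an at least 2.8-fold higher number from compound 2 to compound 1 (0.45 log units; beyond the scatter) and on compound 3 already standing at 104000 nM. The estimate for compound 4 is 150000 nM, expected between 70000 nM and 400000 nM, with a real chance that only a limit is reported.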

Compound 4, half-maximal cytotoxic concentration: > 100000 nM
Compound 4: only a limit was reported (the forecaster's own chance of this, stated with the estimate: 50%); the middle value does not contradict the limit.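

In this assay compound 4 gives > 100000 nM, which is a limit and not a number, so the step from compound 3 to compound 4 cannot be read, because the value is only a limit: the limit of > 100000 nM in this assay, at which 2 of the 4 values shown sit.

The compounds shown leave open how far hydrogen in place of chloro moves the number on the core of compound 3, and whether that shift matches the one seen on the core of compound 2.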